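This account rests on a few compounds, and the source may have more. Where it says the series, first, only, none or still open, it means among the compounds named here.

The measured compounds in a functional assay (Cavia porcellus) with sulfonylurea receptors; K-ATP channels (Homo sapiens) as the target; on this read-out lower numbers stand for stronger inhibition and higher numbers for weaker inhibition:

Compound 1 `CC(O)(C(=O)Nc1ccc(S(=O)(=O)c2ccccc2C#N)cc1)C(F)(F)F` gives 1100 nM.
Compound 2 `CC(O)(C(=O)Nc1ccc(S(=O)(=O)c2ccccc2)c(O)c1)C(F)(F)F` gives 430 nM.
Compound 3 `CC(O)(C(=O)Nc1ccc(S(=O)(=O)c2ccncc2)c(O)c1)C(F)(F)F` gives 1300 nM.

Compound 1 stands second highest of the three numbers in this assay. Its value and that of compound 3 lie within the usual scatter of each other, so no order between them can be read. Compound 2 has the lowest number, and the gap from compound 2 up to compound 1 goes beyond the scatter.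

Compound 4 `CC(O)(C(=O)Nc1ccc(S(=O)(=O)c2nccs2)cc1)C(F)(F)F` has not been measured. It differs from compound 1 in one place: 1,3-thiazol-2-yl in place of 2-cyanophenyl on a sulfonyl sulfur.

Going by the values given here, one measured step bears on this change. Between compound 2 and compound 3, where a six-membered aromatic ring of carbon only on the sulfonyl sulfur gave way to a ring holding a nitrogen, the result was a 3.0-fold higher number from compound 2 to compound 3 (0.48 log units; beyond the scatter). In compound 4 an aromatic ring of carbon only on the sulfonyl sulfur again gives way to a heteroaromatic ring, here a five-membered one with two hetero atoms. Among the compounds with values here, the nitrile carried by the leaving group has no measured counterpart among the three compounds, so its loss cannot be weighed from these data.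

On this basis a modest weakening is expected for compound 4, amounting to a 1.6-fold higher number from compound 1 to compound 4 (0.21 log units; within the scatter), though it may fall within the scatter. Compound 4 is therefore estimated at 1800 nM in this assay, with a range from 600 nM to 5000 nM.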

Compound 4, half-maximal inhibitory concentration: 1400 nM
Estimate against measurement, compound 4: 1.3-fold (0.11 log units) above; the range from low to high includes it.
By their numbers in this assay, from the lowest: compound 2; then compounds 1, 3 and 4 (each within the scatter of the next).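

In this assay, a 1.3-fold higher number from compound 1 to compound 4 (0.10 log units; within the scatter), so on a sulfonyl sulfur whose other neighbour is aromatic carbon, 1,3-thiazol-2-yl can stand in place of 2-cyanophenyl without a difference that can be read, even though the entering group has fewer heavy atoms, a five-membered aromatic ring with 2 hetero atoms and no nitrile. Going by these compounds alone, the only earlier step at this place, a 3.0-fold higher number from compound 2 to compound 3 (0.48 log units; beyond the scatter), was beyond the scatter, but it belongs to a hydroxyl-bearing core that compounds 1 and 4 lack, and the new result shows that a heteroaromatic ring on the sulfonyl sulfur does not have to come with a separation beyond the scatter. Nothing measured here explains why the two groups cannot be told apart on this read-out.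

From the compounds shown here alone, it remains open whether 1,3-thiazol-2-yl would give a similar result on the hydroxyl-bearing core of compound 2, where the closest comparison would be with phenyl. Going by these compounds, it is also open how this place would respond to a thiazole ring carrying an amine or a carboxylic acid, or to a saturated ring such as piperidine on the sulfonyl sulfur.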